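Cytotoxicity notes: aryl swap on the triazole nitrogen

This account rests on a few compounds, and the source may have more. Where it says the series, first, only, none or still open, it means among the compounds named here.

Three ureas sharing one core have been run in a toxicity assay on MRC5 cells (Homo sapiens) for inhibition, read by MTT assay, with a stated time of 72 h; on this read-out lower numbers stand for stronger inhibition and higher numbers for weaker inhibition. Compound 1 `O=C(Nc1cccc(OCc2cn(-c3ccccc3)nn2)c1)Nc1ccc(Cl)c(C(F)(F)F)c1` gives 18400 nM. Compound 2 `COc1cccc(-n2cc(COc3cccc(NC(=O)Nc4ccc(Cl)c(C(F)(F)F)c4)c3)nn2)c1` gives 8570 nM. Compound 3 `CC(C)c1cccc(-n2cc(COc3cccc(NC(=O)Nc4ccc(Cl)c(C(F)(F)F)c4)c3)nn2)c1` gives 21400 nM, the highest of the three numbers; its gap to compound 1 is within the scatter, whereas the step of a 2.5-fold higher number from compound 2 to compound 3 (0.40 log units; beyond the scatter) lies beyond it. The measured steps are a 2.1-fold lower number from compound 1 to compound 2 (0.33 log units; beyond the scatter), a 1.2-fold higher number from compound 1 to compound 3 (0.07 log units; within the scatter) and the one just named.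

Compound 4 `O=C(Nc1cccc(OCc2cn(-c3ccc(Br)cc3)nn2)c1)Nc1ccc(Cl)c(C(F)(F)F)c1` differs from compound 3 by 4-bromophenyl in place of 3-isopropylphenyl on an aromatic nitrogen. For the measured compounds named here, none of the measured steps covers a bromine on that ring, nor a substituent at the position that the 4-bromophenyl carries it; the only steps that bear on it are those above, which vary the same ring and stay modest at most, with the isopropyl-to-hydrogen comparison within the scatter. The expectation in this assay is therefore a number close to that of compound 3, with no step beyond the scatter, as a 1.2-fold lower number from compound 3 to compound 4 (0.08 log units; within the scatter). Compound 4 is estimated at 18000 nM, in a range of 8000 nM to 40000 nM.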

Compound 4, half-maximal inhibitory concentration: 11000 nM
Estimate against measurement, compound 4: 1.6-fold (0.21 log units) above; the range from low to high includes it.
By their numbers in this assay, from the lowest: compounds 2, 4, 1 and 3 (each within the scatter of the next, the first and the last beyond it).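

In this assay, the 4-bromophenyl group on the aromatic nitrogen leaves compound 4 within the scatter of all three other compounds: a 1.7-fold lower number from compound 1 to compound 4 (0.22 log units; within the scatter), a 1.3-fold higher number from compound 2 to compound 4 (0.11 log units; within the scatter) and a 1.9-fold lower number from compound 3 to compound 4 (0.29 log units; within the scatter). For the compounds shown here, a bromo group in place of hydrogen on this ring therefore gives no step that can be told from the scatter, and compound 4 cannot be grouped with either compound 2 or compound 3, although the two of them lie beyond the scatter of each other. Nothing measured here accounts for these numbers.

Open, going by these compounds, is whether an amine or a carboxylic acid on this aryl ring would give a step beyond the scatter. Also open, on these data alone, is whether a longer chain on the ring would do so.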